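Pyrrolidinyl for dimethylamino on a weakly cytotoxic aminothiazole core

The source may report more compounds than this note shows. Statements on the series, on what has been measured and on what is new or still open speak of the compounds shown alone.

Compound 1 `CN(C)c1ccc(-c2nc3c(s2)C(O)CNC3)cc1` is the weaker of the two measured compounds in a functional assay on MCF-10A cells (Homo sapiens) for cytotoxicity, read by sulforhodamine B assay, with a stated time of 2 days (a lower number here means a stronger inhibitor, a higher number a weaker inhibitor), where it gives 70200 nM. Going by the values given here, compound 2 `OCc1cc(N2CCCC2)ccc1-c1nc2c(s1)C(O)CCC2` in this assay gives 17000 nM; it differs from compound 1 in more than one place, so the two values show only that compound 2 sits lower, beyond the scatter. Compound 3 `OC1CNCc2nc(-c3ccc(N4CCCC4)cc3)sc21` keeps the core of compound 1 and differs from it in one place: pyrrolidin-1-yl in place of dimethylamino on an aromatic carbon. Among the compounds with values here, no measured pair isolates this change, so the size of its step is open. The pyrrolidin-1-yl group is shared with compound 2, whose lower value in this assay may hint at a direction, but its other differences leave this uncertain. Compound 3 is therefore expected to move little beyond the scatter, with a small step from a 1.8-fold lower number from compound 1 to compound 3 (0.24 log units; within the scatter) toward a lower number. The estimate for compound 3 in this assay is 40000 nM, within 12000 nM to 130000 nM.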

Compound 3, half-maximal inhibitory concentration: 27800 nM
Estimate against measurement, compound 3: 1.4-fold (0.16 log units) above; the range from low to high includes it.
By their numbers in this assay, from the lowest: compounds 2 and 3 (each within the scatter of the next); then compound 1.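

Placing pyrrolidin-1-yl in place of dimethylamino, on an aromatic carbon para to a large group, gives the first isolated reading of this change: in this assay it is a 2.5-fold lower number from compound 1 to compound 3 (0.40 log units; beyond the scatter). The position therefore responds to this exchange of groups while the core of compound 1 stays the same, and the step runs toward a lower number. Nothing available here accounts for the step.

As far as these compounds go, it remains open whether a piperidin-1-yl or morpholin-4-yl group, or a simple primary amine, at this place would extend the step, hold it or reverse it. Going by these compounds alone, it also remains open whether the same exchange would give a step of similar size on a different core, since only this one pair isolates it.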